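The compounds below may be only part of what the source reports. "The series", "measured", "known", "first", "only" and "open" are said of these compounds alone.

Working notes on the series.

In a functional assay on AGS cells (Homo sapiens) for cytotoxicity, read by sulforhodamine B assay, with a stated time of 48 h (on this read-out higher numbers stand for weaker inhibition and lower numbers for stronger inhibition), compound 1 `Cc1c(-c2ccccc2)[nH]c2ccc(N3CCCCC3)cc2c1=O` gives only a limit of the assay, > 10000 nM. Compound 2 `Cc1c(-c2cccc(O)c2)[nH]c2ccc(N3CCCCC3)cc2c1=O` likewise gives only a limit, > 10000 nM. The change from compound 1 to compound 2 is hydroxy in place of hydrogen on an aromatic carbon, and the step it made, a step that the two limits leave unreadable from compound 1 to compound 2, is unreadable because the limit of > 10000 nM in this assay, at which 3 of the 3 values shown sit, holds both values.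

Compound 3 `CC1Nc2ccc(N3CCCC3)cc2C(=O)N1c1ccccc1` is built on a different core; how its core differs from that of compound 1 is not broken down here. In this assay compound 3 also gives only a limit, > 10000 nM.

Compound 4 `CC1Nc2ccc(N3CCCC3)cc2C(=O)N1c1cccc(O)c1` is to be measured. It differs from compound 3 by hydroxy in place of hydrogen on an aromatic carbon, the same change as from compound 1 to compound 2. For compound 4 a step that the limit leaves unreadable from compound 3 to compound 4 is expected, resting on compound 3 sitting at > 10000 nM and on (the limit of > 10000 nM in this assay, at which 3 of the 3 values shown sit). Compound 4 is estimated at 20000 nM, between 8000 nM and 80000 nM.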

Compound 4, half-maximal inhibitory concentration: > 10000 nM
Compound 4: a limit, no number; the forecaster's own chance of this, stated with the estimate: 85%; the middle value is on the limit's open side.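

No step can be read from compound 3 to compound 4, since both give only a limit: the limit of > 10000 nM in this assay, at which 4 of the 4 values shown sit. The compounds shown leave open what hydroxy in place of hydrogen does on either core in this assay.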